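From 3-Fluorobenzyl to 4-Fluorobenzyl on a Nitro-Bearing Core

This account rests on a few compounds, and the source may have more. Where it says the series, first, only, none or still open, it means among the compounds named here.

Of the compounds shown here, three have so far been measured in a functional assay on MCF7 cells (Homo sapiens) for inhibition, read by MTT assay, with a stated time of 48 h, tested at 10 uM; on this read-out lower numbers stand for less inhibition of growth and higher numbers for more inhibition of growth at the one concentration tested.

Compound 1, `O=C(/C=C/c1ccc(OCc2cn(Cc3cccc(F)c3)nn2)cc1)c1ccc(Br)cc1`, gives 42%.
Compound 2, `O=C(/C=C/c1ccc(OCc2cn(Cc3ccc(F)cc3)nn2)cc1)c1ccc(Br)cc1`, gives 37%.
Compound 3, `O=C(/C=C/c1ccc(OCc2cn(Cc3cccc(F)c3)nn2)cc1)c1ccc([N+](=O)[O-])cc1`, gives 30%.

Compound 2 differs from compound 1 in a single place: 4-fluorophenyl in place of 3-fluorophenyl on a saturated chain carbon bound to an aromatic nitrogen. That change produced a step of a number 5 percentage points lower from compound 1 to compound 2 (within the scatter), so the two values cannot be told apart. Compound 3 differs from compound 1 elsewhere: nitro in place of bromo on an aromatic carbon, a step of a number 12 percentage points lower from compound 1 to compound 3 (beyond the scatter). Compound 3 therefore rests on a different core from compound 1 and compound 2, the core that carries the nitro group rather than the bromo group.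

Compound 4, `O=C(/C=C/c1ccc(OCc2cn(Cc3ccc(F)cc3)nn2)cc1)c1ccc([N+](=O)[O-])cc1`, has not yet been measured. It stands to compound 3 exactly as compound 2 stands to compound 1: 4-fluorophenyl in place of 3-fluorophenyl on a saturated chain carbon bound to an aromatic nitrogen. The place of the change is the same in both pairs, so this is the same change, made for the second time among these compounds, now on the nitro-bearing core.

Within the data shown here, the only guide to its size is the earlier step, which stayed within the scatter. Set beside it, the step from compound 3 to compound 4 is expected to be a number 4 percentage points lower from compound 3 to compound 4 (within the scatter), equally small, because the earlier change gave a number 5 percentage points lower from compound 1 to compound 2 (within the scatter). Whether the nitro-bearing core behaves the same way is not known, so the range is kept wide. For compound 4 the value in this assay is therefore estimated at 26%, somewhere between 14% and 38%.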

Compound 4, percent growth inhibition at one concentration: 38%
The estimate for compound 4 lay 12 percentage points below the measured number; measured number inside the range.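

In this assay, the change to 4-fluorophenyl on the saturated chain carbon bound to the aromatic nitrogen gave a number 8 percentage points higher from compound 3 to compound 4 (within the scatter), and set beside the same change on the core of compound 1, it shows no difference that can be told from scatter: the same change on two cores in this assay, a number 5 percentage points lower (within the scatter) from compound 1 to compound 2 and a number 8 percentage points higher (within the scatter) from compound 3 to compound 4, 13 percentage points apart, within the scatter of two such steps. The change from bromo to nitro, made with the 4-fluorobenzyl group in place, gave a number 1 percentage points higher from compound 2 to compound 4 (within the scatter), and this step also cannot be told apart from its earlier counterpart: the same change on two cores in this assay, a number 12 percentage points lower (beyond the scatter) from compound 1 to compound 3 and a number 1 percentage points higher (within the scatter) from compound 2 to compound 4, 13 percentage points apart, within the scatter of two such steps. Among these compounds, both changes are therefore compatible with carrying over from one core to the other, but this does not prove that their steps are equal, and with only two cores and steps of this size, a real difference could stay hidden.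

The compounds shown leave open how other groups would read in these places, such as an amine or a methoxy group in place of bromo or nitro, or a plain benzyl group or a longer chain in place of the fluorobenzyl groups. As far as these compounds go, all four values come from a single concentration in this assay, so whether the same picture holds at other concentrations also stays open.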